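The source may hold more compounds than are shown below. What is called first, only, known or untested is meant among the compounds shown, and "the series" means these compounds.

Compound 2 `COc1ccc(NC2=CC(=O)c3nc4n(c3C2=O)[C@H]2OC[C@@H](O)[C@H]2OC4)cc1` is the compound that gives a definite number in a functional assay on HeLa cells (Homo sapiens) for inhibition, read by sulforhodamine B assay; a higher number here means a weaker inhibitor, a lower number a stronger inhibitor: in that test compound 2 gives 4780 nM. Compound 1 `O=C1C=C(NC2CCCC2)C(=O)c2c1nc1n2[C@H]2OC[C@@H](O)[C@H]2OC1` carries a cyclopentyl on the amine nitrogen where compound 2 carries a 4-methoxyphenyl. In this assay compound 1 reaches only a limit of the assay, > 16000 nM, and so its real value is not known (the limit of > 16000 nM in this assay, at which 1 of the 2 values shown sits). Within the data shown here, the single measured step, an at least 3.3-fold lower number from compound 1 to compound 2 (0.52 log units; beyond the scatter), is therefore only a lower bound on how much that swap changed the result. Compound 3 `COc1cccc(NC2=CC(=O)c3nc4n(c3C2=O)[C@H]2OC[C@@H](O)[C@H]2OC4)c1` differs from compound 2 in one place: 3-methoxyphenyl in place of 4-methoxyphenyl on an amine nitrogen. Among the measured compounds shown here, no measured step covers this kind of change, where the same atoms are joined differently on the aromatic ring, so there is no basis to expect a shift beyond the scatter, and the step from compound 2 to compound 3 is estimated to be small: a 1.0-fold higher number from compound 2 to compound 3 (0.02 log units; within the scatter). For compound 3 the expected value in this assay is 5000 nM, with a range from 1500 nM to 16000 nM.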

Compound 3, half-maximal inhibitory concentration: 4280 nM
Beside the measured number, compound 3's estimate is 1.2-fold (0.07 log units) above it; the range from low to high includes it.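

In this assay, moving the methoxy group around the aromatic ring gives a 1.1-fold lower number from compound 2 to compound 3 (0.05 log units; within the scatter), so at this amine nitrogen the 4-methoxyphenyl and 3-methoxyphenyl groups cannot be told apart. The second methoxyphenyl group also stands against cyclopentyl, with an at least 3.7-fold lower number from compound 1 to compound 3 (0.57 log units; beyond the scatter), so the lower number seen earlier is not tied to one placement of the methoxy group. The true size of this step remains unknown, because one end of it is a limit of the assay: the limit of > 16000 nM in this assay, at which 1 of the 3 values shown sits.

Going by these compounds, whether the methoxy group itself contributes remains open, and a plain phenyl group on the same nitrogen would address that. Also open, on these data alone, is how a 2-methoxyphenyl group, or a different ring substituent such as chlorine or an amine, would read.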